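The source may hold more compounds than are shown below. What is called first, only, known or untested is meant among the compounds shown, and "the series" means these compounds.

Measured in a functional assay on MCF7 cells (Homo sapiens) for cytotoxicity, read by sulforhodamine B assay, with a stated time of 72 h; a lower number here means a stronger inhibitor, a higher number a weaker inhibitor:
compound 1 `CC(=O)c1nn(-c2ccccc2)/c(=N/c2nc(-c3c(C)n(C)n(-c4ccccc4)c3=O)cs2)s1` gives > 100000 nM, a limit of the assay.
compound 2 `CC(=O)c1nn(-c2ccc(Cl)cc2)/c(=N/c2nc(-c3c(C)n(C)n(-c4ccccc4)c3=O)cs2)s1` gives > 100000 nM, likewise a limit.
compound 3 `COc1ccc(-n2nc(C(C)=O)s/c2=N\c2nc(-c3c(C)n(C)n(-c4ccccc4)c3=O)cs2)cc1` gives 64500 nM.

Among the compounds with values here, compound 3 thus holds the only true number among the three; the other two values are limits, not measurements. The step of an at least 1.5-fold lower number from compound 1 to compound 3 (0.19 log units; that floor lies within the scatter) and the step of an at least 1.5-fold lower number from compound 2 to compound 3 (0.19 log units; that floor lies within the scatter) each reach only a floor that lies within the scatter, and a step that the two limits leave unreadable from compound 1 to compound 2 cannot be read at all. Compound 4 `CC(=O)c1nn(-c2ccc([N+](=O)[O-])cc2)/c(=N/c2nc(-c3c(C)n(C)n(-c4ccccc4)c3=O)cs2)s1` differs from compound 3 by nitro in place of methoxy on an aromatic carbon. Within the data shown here, neither hydrogen nor chloro at that place produced a readable number, and no measured step covers nitro, so a weak result is expected, with a fair chance of another limit. Compound 4 is estimated at 90000 nM, between 30000 nM and 300000 nM, an expected step of a 1.4-fold higher number from compound 3 to compound 4 (0.14 log units; within the scatter).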

Compound 4, half-maximal inhibitory concentration: > 100000 nM
Compound 4 gave a limit, no number (the forecaster's own chance of this, stated with the estimate: 50%); middle value at least 1.1-fold (0.04 log units) away from the limit.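

In this assay, nitro in place of methoxy gives an at least 1.5-fold higher number from compound 3 to compound 4 (0.19 log units; that floor lies within the scatter), so a fourth group at this place still yields no step beyond the scatter. Compound 4 adds another limit, not a number: the limit of > 100000 nM in this assay, at which 3 of the 4 values shown sit. Within the data shown here, the steps to compound 4 from compound 1 and from compound 2 cannot be read, and methoxy remains the only group here with a true number.

Going by these compounds, how far the three limits lie from one another stays open. So does whether an amine or a hydroxyl at this place would give a clearly lower number.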